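This account rests on a few compounds, and the source may have more. Where it says the series, first, only, none or still open, it means among the compounds named here.

Of the compounds shown here, three have been tested so far in an ADME assay on H1-HeLa cells (Homo sapiens) for cytotoxicity, read by MTT assay, with a stated time of 3 days; on this read-out lower numbers stand for higher toxicity in this test and higher numbers for lower toxicity in this test. Compound 1, with the structure `CNC(=O)c1cc(Oc2ccc(-c3noc(CC(C)C)n3)cc2)ccn1`, gives 23400 nM in this assay. Compound 2, with the structure `CNC(=O)c1cc(Oc2c(C)cc(-c3noc(C(C)C)n3)cc2C)ccn1`, gives 7400 nM in this assay. Compound 3, with the structure `CC(C)c1nc(-c2ccc(Oc3ccnc(C(=O)N(C)C)c3)cc2)no1`, gives 9000 nM in this assay. Compound 2 thus shows the lowest of the three numbers, but its gap to compound 3 lies within the usual scatter, so the two cannot be told apart; only its gap to compound 1 lies beyond the scatter.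

Compound 4, with the structure `Cc1cc(-c2noc(C(C)C)n2)cc(C)c1Oc1ccnc(C(=O)N(C)C)c1`, is not yet measured. It differs from compound 2 by a single change: methyl in place of hydrogen on an amide-type nitrogen. Among the compounds with values here, no pair of measured compounds differs by this change alone, so its effect in this assay is unknown. Compound 3 also carries the dimethylamide, but it differs from compound 2 in other places as well, so their values show only that both lie in the same region. The step from compound 2 to compound 4 is therefore expected to be small, at a 1.0-fold higher number from compound 2 to compound 4 (0.01 log units; within the scatter), with no direction beyond the scatter. Compound 4 is expected to give about 7500 nM in this assay, within a range from 3000 nM to 18000 nM.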

Compound 4, half-maximal cytotoxic concentration: 1800 nM
The estimate for compound 4 lay 4.2-fold (0.62 log units) above the measured number, and the stated range ends above it.
By their numbers in this assay, from the lowest: compound 4; then compounds 2 and 3 (each within the scatter of the next); then compound 1.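

Within the data shown here, changing methylcarbamoyl to dimethylcarbamoyl gives the first single-place comparison in this assay, with a 4.1-fold lower number from compound 2 to compound 4 (0.61 log units; beyond the scatter), in the direction of higher toxicity in this test. This shows that the amide hydrogen is not a neutral spot on this scaffold: replacing it with one methyl, a single added carbon, is enough on its own to move the read-out beyond the scatter. Nothing measured here gives a reason for the step.

From the compounds shown here alone, whether the same change has a similar effect on the core of compound 1 or compound 3 remains open, as this single pair cannot show whether the step carries over to other cores. Going by these compounds, it is also open how an ethyl group, a longer chain or a carboxylic acid at this amide position would read.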